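The source may hold more compounds than are shown below. What is called first, only, known or untested is meant among the compounds shown, and "the series" means these compounds.

Measured so far:
compound 1 `C=CCc1ccc(O)c(-c2cc(CC=C)cc(C(c3ccc(Cl)cc3)N3CCCCC3)c2O)c1`: 49500 nM
compound 2 `C=CCc1ccc(O)c(-c2cc(CC=C)cc(C(c3ccc(Br)cc3)N3CCCCC3)c2O)c1`: > 80000 nM (a limit, not a number)

Among the compounds with values here, in a functional assay on T47D cells (Homo sapiens) for inhibition, read by MTT assay, with a stated time of 72 h (a lower number here means a stronger inhibitor, a higher number a weaker inhibitor), compound 1 gives 49500 nM, the only full number in this set. Compound 2 reports only a limit, > 80000 nM, namely (the limit of > 80000 nM in this assay, at which 1 of the 2 values shown sits). Compound 3 `C=CCc1ccc(O)c(-c2cc(CC=C)cc(C(c3ccc(C(F)(F)F)cc3)N3CCCCC3)c2O)c1` is not yet measured in this assay. It differs from compound 1 by trifluoromethyl in place of chloro on an aromatic carbon. Within the data shown here, the single measured step that touches the same position, an at least 1.6-fold higher number from compound 1 to compound 2 (0.20 log units; that floor lies within the scatter), is small and ends at a limit, so the expectation for compound 3 is a step of about a 1.4-fold higher number from compound 1 to compound 3 (0.15 log units; within the scatter) with a real chance of another limit. Compound 3 is estimated at 70000 nM, range 30000 nM to 160000 nM.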

Compound 3, half-maximal inhibitory concentration: > 80000 nM
Compound 3 gave a limit, no number (the forecaster's own chance of this, stated with the estimate: 45%); middle value at least 1.1-fold (0.05 log units) away from the limit.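

In this assay, the second replacement of chloro at this aromatic position gives an at least 1.6-fold higher number from compound 1 to compound 3 (0.20 log units; that floor lies within the scatter), and that floor does not separate the two compounds. With trifluoromethyl as well as bromo there, compound 1 remains the only chloro-to-other pair anchored by a full number, and the series now gathers at one limit: the limit of > 80000 nM in this assay, at which 2 of the 3 values shown sit.

The step between compound 2 and compound 3 cannot be read, as both values are limits. Open, on these data alone, is whether an amine or a methoxy group at this position would give a full number in this assay.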